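A few compounds are considered here, and "the series" means these few. Any claim that something is new, unique, unknown or untested is made for them only; others in the source may bear on it.

Compound 1 `Cc1ccc(NS(=O)(=O)c2ccc(N3CCNC3=O)cc2)cc1` gives 480 nM in a functional assay on HT-29 cells (Homo sapiens) for antiproliferative activity, read by sulforhodamine B assay, with a stated time of 48 h; a lower number here means a stronger inhibitor, a higher number a weaker inhibitor.
Compound 2 `O=C1NCCN1c1ccc(S(=O)(=O)Nc2ccc(I)cc2)cc1` gives 650 nM.
Compound 3 `Cc1ccc(C)c(NS(=O)(=O)c2ccc(N3CCNC3=O)cc2)c1` gives 46 nM.

In this assay compound 1 stands second highest of the three numbers: its nearest neighbour is compound 2, with a 1.4-fold higher number from compound 1 to compound 2 (0.13 log units; within the scatter), and its furthest is compound 3, with a 10-fold lower number from compound 1 to compound 3 (1.02 log units; beyond the scatter). Compound 4 `COc1ccc(NS(=O)(=O)c2ccc(N3CCNC3=O)cc2)cc1` differs from compound 1 by methoxy in place of methyl on an aromatic carbon. For the measured compounds named here, only one measured step swaps a group on an aromatic carbon in the same way, the step from compound 1 to compound 2, and it stayed within the scatter; the large step to compound 3 changes the whole phenyl pattern and offers no guidance here. A step within the scatter is therefore expected. Compound 4 is estimated at 500 nM, with a range of 200 nM to 1300 nM. This estimate means an expected step of a 1.0-fold higher number from compound 1 to compound 4 (0.02 log units; within the scatter).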

Compound 4, half-maximal inhibitory concentration: 800 nM
For compound 4 the middle estimate is 1.6-fold (0.20 log units) below the measured one; measured number inside the range.
By their numbers in this assay, from the lowest: compound 3; then compounds 1, 2 and 4 (each within the scatter of the next).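

Methoxy in place of methyl para to a large group gives a 1.7-fold higher number from compound 1 to compound 4 (0.22 log units; within the scatter) in this assay and methoxy in place of iodo gives a 1.2-fold higher number from compound 2 to compound 4 (0.09 log units; within the scatter) and so methyl, iodo and methoxy at this place have numbers within the scatter of each other. The 2,5-dimethylphenyl group still stands apart, with a 17-fold higher number from compound 3 to compound 4 (1.24 log units; beyond the scatter) on going to the 4-methoxyphenyl group. No measurement here explains these numbers.

On these data alone, whether an amine or a carboxylic acid at this place would move the number stays open. So does whether a single methyl on the ring of compound 3 would match it.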